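From Compound 2 to Compound 3: A Ring Exchange

The source may report more compounds than this note shows. Statements on the series, on what has been measured and on what is new or still open speak of the compounds shown alone.

In a physicochemical assay for lipophilicity, using the shake flask method, in phosphate buffer, measured as octanol-water partition, with a stated time of 5 h, at pH 7.4 (a higher number here means a more lipophilic compound, a lower number a more polar compound), compound 1 (`CN1CCN(c2cc(Nc3ncc(F)c(Nc4cccc(CO)c4)n3)cc(S(C)(=O)=O)c2)CC1`) gives 1.84. Compound 2 (`Cc1cnc(Nc2cc(N3C[C@@H]4C[C@H]3CN4C)cc(S(C)(=O)=O)c2)nc1Nc1cccc(CO)c1`) gives 0.82, the lower of the two numbers available, and the gap between these two compounds lies beyond the scatter. Compound 3 (`Cc1cnc(Nc2cc(N3CCN(C)CC3)cc(S(C)(=O)=O)c2)nc1Nc1cccc(CO)c1`) differs from compound 2 at one place, on an aromatic carbon, where 4-methylpiperazin-1-yl enters: a group of 7 heavy atoms (5 carbon, 2 nitrogen; one six-membered non-aromatic ring with 2 hetero atoms) in place of a group of 8 heavy atoms (6 carbon, 2 nitrogen; 2 five-membered non-aromatic rings with 1 hetero atom each), on an aromatic carbon. Compound 1 bears the same group on a core that is not identical, and with compound 1 at 1.84, an upward step beyond the scatter is expected in this assay. The estimated change is a number 0.78 log units higher from compound 2 to compound 3 (beyond the scatter). Compound 3 is expected at 1.6, with an estimated range of 1.2 to 2.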

Compound 3, distribution coefficient: 1.74
Estimate against measurement, compound 3: 0.14 log units below; the measured number falls inside the stated range.
By their numbers in this assay, from the lowest: compound 2; then compounds 3 and 1 (each within the scatter of the next).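

On this aromatic carbon, 4-methylpiperazin-1-yl in place of the group with two five-membered rings gives a number 0.92 log units higher from compound 2 to compound 3 (beyond the scatter) in this assay and shows the size of this ring exchange with the rest of the structure unchanged. Methyl in place of fluoro on an aromatic carbon gives a number 0.10 log units lower from compound 1 to compound 3 (within the scatter), so this second change shows no step beyond the scatter with 4-methylpiperazin-1-yl present. The data offer no evidence for a cause of either step.

Going by these compounds, it remains open where a morpholine ring or an open-chain diamine at this place would fall in this assay relative to compound 2 and compound 3. On these data alone, it also remains open whether methyl and fluoro would stay within the scatter of each other with the group with two five-membered rings in place.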